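Pivaloyl amide to methanesulfonamide on a weakly active series

The source may report more compounds than this note shows. Statements on the series, on what has been measured and on what is new or still open speak of the compounds shown alone.

The measured compounds and their values:
compound 1 `CC(C)(C)C(=O)Nc1ccc(-c2cccc(C(=O)N[C@H]3CN[C@@H](C(=O)Nc4ccc(Cl)c(C(F)(F)F)c4)C3)c2)cn1` 28000 nM
compound 2 `CCN(CC)C(=O)c1cncc(-c2ccc(C(=O)N[C@H]3CN[C@@H](C(=O)Nc4ccc(Cl)c(C(F)(F)F)c4)C3)cc2)c1` 55500 nM
compound 3 `CC(=O)Nc1ccc(-c2cccc(C(=O)N[C@@H](C)C(=O)Nc3ccc(Cl)c(C(F)(F)F)c3)c2)cn1` 42800 nM

All three numbers come from a functional assay on K562 cells (Homo sapiens) for inhibition, read by MTT assay, with a stated time of 48 h; on this read-out lower numbers stand for stronger inhibition and higher numbers for weaker inhibition. Compound 1 gives the lowest of the three, but compound 3 lies within the scatter of it, and so does compound 2; no order among them can be claimed. Compound 4 `CS(=O)(=O)Nc1ccc(-c2cccc(C(=O)N[C@H]3CN[C@@H](C(=O)Nc4ccc(Cl)c(C(F)(F)F)c4)C3)c2)cn1` is not yet measured. It differs from compound 1 in one place: methylsulfonyl in place of (tert-butyl)carbonyl on a nitrogen on an aromatic ring, that is, ((tert-butyl)carbonyl)amino becomes methanesulfonamido. Among the measured compounds shown here, no pair in the measured set shows this change, so the expected step from compound 1 to compound 4 is a 1.1-fold higher number from compound 1 to compound 4 (0.03 log units; within the scatter), none beyond the scatter. Compound 4 is therefore estimated at 30000 nM, with a range from 10000 nM to 90000 nM.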

Compound 4, half-maximal inhibitory concentration: 24600 nM
Compound 4: middle estimate off by 1.2-fold (0.09 log units), on the high side; the measured number falls inside the stated range.
By their numbers in this assay, from the lowest: compounds 4, 1, 3 and 2 (each within the scatter of the next, the first and the last beyond it).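

In this assay, methylsulfonyl in place of (tert-butyl)carbonyl on a nitrogen on an aromatic ring gives a 1.1-fold lower number from compound 1 to compound 4 (0.06 log units; within the scatter), so no difference between the two groups can be claimed. At this position, a group of six heavy atoms with no sulfur and one of four heavy atoms with sulfur therefore read alike in this cell assay. No accompanying measurement offers an account of this result.

The compounds shown leave open whether a free amine on this nitrogen, or a longer acyl chain such as hexanoyl, would move the number beyond the scatter.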